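From pyridin-3-yl to pyridin-4-yl: notes on compound 3

The compounds below may be only part of what the source reports. "The series", "measured", "known", "first", "only" and "open" are said of these compounds alone.

Of the compounds shown here, two have been measured so far in a functional assay for inhibition, with Homo sapiens as the target; on this read-out lower numbers stand for stronger inhibition and higher numbers for weaker inhibition. Compound 1 (`NS(=O)(=O)c1ccc(Nc2nccc(-c3ccncc3)n2)cc1`) gives 5100 nM, and compound 2 (`CC1CCN(c2ccc(Nc3nccc(-c4cccnc4)n3)cc2)CC1`) gives 500 nM. Compound 2 therefore holds the lower of the two numbers, and its gap to compound 1 lies beyond the usual scatter.

Compound 3 (`CC1CCN(c2ccc(Nc3nccc(-c4ccncc4)n3)cc2)CC1`) has not yet been measured. It has the same atoms as compound 2, joined differently: pyridin-4-yl in place of pyridin-3-yl on an aromatic carbon. Pyridin-4-yl stands in place of pyridin-3-yl on an aromatic carbon of a six-membered aromatic ring with 2 nitrogen.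

Among the measured compounds shown here, no measured pair isolates this exchange, so the data give no direct guide to its direction. Starting from compound 2 at 500 nM, no shift beyond the scatter is expected in this assay. The expected change is small, estimated as a 1.2-fold higher number from compound 2 to compound 3 (0.08 log units; within the scatter), and the margin around it remains wide. For compound 3 the estimated value is 600 nM, with an expected range of 150 nM to 2400 nM.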

Compound 3, half-maximal inhibitory concentration: 600 nM
Compound 3: the middle estimate sits on the measured number at the digits printed; the measured number falls inside the stated range.
By their numbers in this assay, from the lowest: compounds 2 and 3 (each within the scatter of the next); then compound 1.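

At the aromatic carbon next to the ring nitrogen, pyridin-4-yl in place of pyridin-3-yl gives a 1.2-fold higher number from compound 2 to compound 3 (0.08 log units; within the scatter) in this assay, so this exchange leaves the read-out within the scatter when 4-methylpiperidin-1-yl is the other substituent. Among the compounds shown here, the new structure also allows the first single-place comparison of the other substituent: with pyridin-4-yl common to both, 4-methylpiperidin-1-yl in place of sulfamoyl gives an 8.5-fold lower number from compound 1 to compound 3 (0.93 log units; beyond the scatter), and of the two steps only this one lies beyond the scatter. No measurement at hand accounts for either step.

As far as these compounds go, whether the pyridin-4-yl and pyridin-3-yl exchange stays within the scatter with sulfamoyl as the other substituent remains open, and so does the effect on the read-out of a plain phenyl ring, which has no ring nitrogen, at the same aromatic carbon. Also open, from the compounds shown here alone, is how far the read-out depends on the 4-methylpiperidin-1-yl group itself, which morpholin-4-yl or a simple dimethylamino group in its place would begin to test.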